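The compounds below may be only part of what the source reports. "The series", "measured", "known", "first", "only" and "open" are said of these compounds alone.

Of the compounds shown here, three have been tested in a functional assay on the whole organism for inhibition, with Rattus norvegicus as the target; a lower number here means that less compound is needed, a higher number that more compound is needed for the effect. Compound 1 `O=C(O)C(Cc1ccc(Cl)cc1)Oc1ccccc1` gives > 25 mg/kg, which is a limit of the assay rather than a number. Compound 2 `COc1ccc(OC(Cc2ccc(Cl)cc2)C(=O)O)cc1` likewise gives > 25 mg/kg, again only a limit. The change between them is methoxy in place of hydrogen on an aromatic carbon, and the resulting step that the two limits leave unreadable from compound 1 to compound 2 cannot be read, because of the limit of > 25 mg/kg in this assay, at which 2 of the 3 values shown sit. Going by the values given here, compound 3 `CC(Cc1ccc(Cl)cc1)(Oc1ccc(Cc2ccccc2)cc1)C(=O)O` gives 1 mg/kg, the only true number among the three; how its core differs from the core of compound 1 is not broken down here. Compound 4 `COc1ccc(Cc2ccc(OC(C)(Cc3ccc(Cl)cc3)C(=O)O)cc2)cc1` has not yet been measured. It differs from compound 3 by methoxy in place of hydrogen on an aromatic carbon, the same change that leads from compound 1 to compound 2, at the same kind of position. Among the compounds with values here, since the step from compound 1 to compound 2 is unreadable, no measured step tells how large this change is, and the expectation rests on compound 3 alone. Compound 4 is therefore expected to give 1.2 mg/kg in this assay, with a likely range from 0.4 mg/kg to 4 mg/kg. The expected 1.2-fold higher number from compound 3 to compound 4 (0.08 log units; within the scatter) is estimated to stay within the usual scatter.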

Compound 4, dose for half-maximal effect: < 10 mg/kg
Compound 4 was reported as a limit; the forecaster's own chance of this, stated with the estimate: 5%; the middle value does not contradict the limit.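

In this assay compound 4 gives < 10 mg/kg, which is a limit of the assay and not a number. The size of the step from compound 3 to compound 4 therefore cannot be read: the limit of < 10 mg/kg in this assay, at which 1 of the 4 values shown sits.

The compounds shown leave open how far methoxy in place of hydrogen on an aromatic carbon shifts the dose needed, both between compound 1 and compound 2 and between compound 3 and compound 4.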